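Trifluorobutyl to cycloheptyl on the aromatic nitrogen

A few compounds are considered here, and "the series" means these few. Any claim that something is new, unique, unknown or untested is made for them only; others in the source may bear on it.

Measured so far in a functional assay on HT-29 cells (Homo sapiens) for inhibition, read by luminescence and CellTiter-Glo, with a stated time of 24 h (on this read-out lower numbers stand for an effect already at smaller amounts and higher numbers for an effect only at larger amounts of compound), by compound
compound 1 `CCCn1nc(C(=O)N[C@H]2COc3ccccc3N(C)C2=S)nc1Cc1ccccc1` gives 288 nM
compound 2 `CCCCCn1nc(C(=O)N[C@H]2COc3ccccc3N(C)C2=S)nc1Cc1ccccc1` gives 805 nM
compound 3 `CN1C(=S)[C@@H](NC(=O)c2nc(Cc3ccccc3)n(CCCC(F)(F)F)n2)COc2ccccc21` gives 2380 nM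

Compound 3 at 2380 nM has the highest number of the three, with compound 2 nearest and compound 1 furthest. Compound 4 `CN1C(=S)[C@@H](NC(=O)c2nc(Cc3ccccc3)n(C3CCCCCC3)n2)COc2ccccc21` keeps the shared core and the benzyl group. The change is cycloheptyl in place of 4,4,4-trifluorobutyl on an aromatic nitrogen on an aromatic nitrogen of the five-membered aromatic ring with 3 nitrogen.

All three measured steps concern open chains on this same nitrogen. They are a 2.8-fold higher number from compound 1 to compound 2 (0.45 log units; beyond the scatter) and an 8.3-fold higher number from compound 1 to compound 3 (0.92 log units; beyond the scatter) and a 3.0-fold higher number from compound 2 to compound 3 (0.47 log units; beyond the scatter) and each is modest but beyond the scatter. For the measured compounds named here, no measured compound carries a ring at this place, so these steps bear on the change only indirectly and set a likely size for it rather than a direction. Since compound 3 at 2380 nM sits at the top of the measured values, a modest move towards a lower number is the more likely outcome, though a higher number cannot be ruled out. An estimated 2.0-fold lower number from compound 3 to compound 4 (0.30 log units; within the scatter) is expected in this assay on this basis. The estimated value for compound 4 is 1200 nM within an expected range of 250 nM to 5500 nM in this read-out.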

Compound 4, half-maximal effective concentration: 5530 nM
Estimate against measurement, compound 4: 4.6-fold (0.66 log units) below; the measured number lies above the stated range.
By their numbers in this assay, from the lowest: compound 1; then compound 2; then compound 3; then compound 4.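

In this assay, the first ring on this aromatic nitrogen gives no gain over the open chains: cycloheptyl in place of 4,4,4-trifluorobutyl gives a 2.3-fold higher number from compound 3 to compound 4 (0.37 log units; beyond the scatter), so the move to an all-carbon ring does not recover what the trifluorobutyl chain lost. For the compounds shown here, the gap widens against the plain chains, with cycloheptyl in place of pentyl giving a 6.9-fold higher number from compound 2 to compound 4 (0.84 log units; beyond the scatter) and cycloheptyl in place of propyl giving a 19-fold higher number from compound 1 to compound 4 (1.28 log units; beyond the scatter), the only large step, and compound 4 now has the highest number of the four, its steps to all the others being beyond the scatter. Nothing measured here bears on why this seven-membered ring stands above the chains at this position.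

Still open, on these data alone, is whether the ring as such or its size sets the number, a question that a cyclopentyl or cyclopropyl group, set against a branched chain such as isopropyl, could separate on this nitrogen. As far as these compounds go, compound 1 gives 288 nM, and also open is whether any group here can reach a still lower number, for instance a shorter ethyl chain or a propyl chain ending in an amine or a hydroxyl.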